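Thiazole for Thiadiazole on the Ring Nitrogen Substituent

The source may report more compounds than this note shows. Statements on the series, on what has been measured and on what is new or still open speak of the compounds shown alone.

Of the compounds shown here, three sharing one core have been measured in a functional assay on HCT-116 cells (Homo sapiens) for inhibition, read by MTT assay, with a stated time of 48 h, tested at 2 uM; on this read-out lower numbers stand for less inhibition and higher numbers for more inhibition at the one concentration tested (going by the name of the read-out). Compound 1 `Cc1noc(C)c1-c1ccc2c(c1)C(c1ccccc1)NC(=O)N2C`, which carries hydrogen on the amide-type nitrogen in the ring, gives 27.8%. Compound 2 `Cc1noc(C)c1-c1ccc2c(c1)C(c1ccccc1)N(Cc1nnc(-c3ccccc3)s1)C(=O)N2C` gives 26.9%, and compound 3 `Cc1nc(-c2ccc(F)cc2)sc1CN1C(=O)N(C)c2ccc(-c3c(C)noc3C)cc2C1c1ccccc1` gives 26%. Compound 2 stands second highest of the three numbers, yet all three lie within the usual scatter of each other, so no order among them can be read.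

Compound 4 `Cc1noc(C)c1-c1ccc2c(c1)C(c1ccccc1)N(Cc1csc(-c3ccc(F)cc3)n1)C(=O)N2C` is the next compound, differing from compound 2 only in the group on the saturated chain carbon bound to the amide-type nitrogen in the ring: 2-(4-fluorophenyl)-1,3-thiazol-4-yl in place of 5-phenyl-1,3,4-thiadiazol-2-yl on a saturated chain carbon bound to an amide-type nitrogen in a ring. Going by the values given here, the one measured step that bears on this position is the attachment of the whole group, a number 0.9 percentage points lower from compound 1 to compound 2 (within the scatter). Since adding a substituent there left the inhibition unchanged, and compound 3, bearing a related fluorophenyl-thiazole, sits in the same band, he expects no step beyond the scatter, a number 0.4 percentage points lower from compound 2 to compound 4 (within the scatter). Compound 4 is therefore estimated at 26.5%, within 15% to 38%.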

Compound 4, a percentage reported as inhibition, at one concentration (the size of the read-out at that concentration, not a potency): 31.8%
For compound 4 the middle estimate is 5.3 percentage points below the measured one, within the range that was stated.
By their numbers in this assay, from the lowest: compounds 3, 2, 1 and 4 (each within the scatter of the next).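

In this assay, the change of ring group gives a number 4.9 percentage points higher from compound 2 to compound 4 (within the scatter). Where the earlier step concerned only attaching a group to the amide-type nitrogen in the ring, this pair shows that the group on the saturated chain carbon can also be exchanged for a different aromatic pair of rings with no difference that can be read. The exchange alters the five-membered ring and brings in fluorine at once, so the two changes cannot be told apart, and nothing available offers a reason for the size of this step.

The compounds shown leave open whether 2-phenyl-1,3-thiazol-4-yl, without the fluorine, would read the same. They also leave open whether an amine, a carboxylic acid or a longer chain at this place would give a step beyond the scatter.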